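Dichlorobenzyl Swap Carried onto the Dimethylamino Analogue

A few compounds are considered here, and "the series" means these few. Any claim that something is new, unique, unknown or untested is made for them only; others in the source may bear on it.

Measured compounds:
Compound 1, `CCN(CC)Cc1ccc2nc(NC(=O)N/N=C/c3cn(Cc4ccc(Cl)cc4Cl)c4ccccc34)sc2c1`, gives 1900 nM in a functional assay on A549 cells (Homo sapiens) for cytotoxicity, read by MTT assay, with a stated time of 72 h; on this read-out higher numbers stand for weaker inhibition and lower numbers for stronger inhibition.
Compound 2, `CCN(CC)Cc1ccc2nc(NC(=O)N/N=C/c3cn(Cc4cccc(Cl)c4)c4ccccc34)sc2c1`, gives 2410 nM in this assay.
Compound 3, `CN(C)Cc1ccc2nc(NC(=O)N/N=C/c3cn(Cc4cccc(Cl)c4)c4ccccc34)sc2c1`, gives 1240 nM in this assay.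

Compound 4, `CN(C)Cc1ccc2nc(NC(=O)N/N=C/c3cn(Cc4ccc(Cl)cc4Cl)c4ccccc34)sc2c1`, is not yet measured. It differs from compound 3 by 2,4-dichlorophenyl in place of 3-chlorophenyl on a saturated chain carbon bound to an aromatic nitrogen. The same change is already seen between measured compounds, (2,4-dichlorophenyl in place of 3-chlorophenyl on a saturated chain carbon bound to an aromatic nitrogen), where it made a 1.3-fold lower number from compound 2 to compound 1 (0.10 log units; within the scatter). The cores of compound 3 and compound 2 differ by dimethylamino in place of diethylamino on a saturated chain carbon bound to an aromatic carbon, a change that made a 1.9-fold lower number from compound 2 to compound 3 (0.29 log units; within the scatter). All three measured numbers lie within the scatter of one another, so no order among them can be claimed.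

Because the earlier step of a 1.3-fold lower number from compound 2 to compound 1 (0.10 log units; within the scatter) was small, compound 4 is expected to stay close to compound 3, with an estimated step of a 1.2-fold lower number from compound 3 to compound 4 (0.09 log units; within the scatter). The estimated value for compound 4 in this assay is 1000 nM, expected between 450 nM and 2300 nM.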

Compound 4, half-maximal inhibitory concentration: 2000 nM
Compound 4: middle estimate off by 2.0-fold (0.30 log units), on the low side; measured number inside the range.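

In this assay, going from 3-chlorobenzyl to 2,4-dichlorobenzyl on the dimethylamino core gives a 1.6-fold higher number from compound 3 to compound 4 (0.21 log units; within the scatter) and does not differ measurably from the same change on the diethylamino core: the same change on two cores in this assay, a 1.3-fold lower number (0.10 log units; within the scatter) from compound 2 to compound 1 and a 1.6-fold higher number (0.21 log units; within the scatter) from compound 3 to compound 4, 2.0-fold (0.31 log units) apart, within the scatter of two such steps.
Dimethylamino in place of diethylamino, now carried onto the 2,4-dichlorobenzyl compounds, gives a 1.1-fold higher number from compound 1 to compound 4 (0.02 log units; within the scatter) and likewise matches its earlier step: the same change on two cores in this assay, a 1.9-fold lower number (0.29 log units; within the scatter) from compound 2 to compound 3 and a 1.1-fold higher number (0.02 log units; within the scatter) from compound 1 to compound 4, 2.0-fold (0.31 log units) apart, within the scatter of two such steps.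
Neither change can be told apart between the two cores, but with every step this small, the data do not show that either change shifts the number at all, or that it would transfer reliably to another core.

As far as these compounds go, it remains open whether a cyclic amine such as morpholine in place of dimethylamino, or an unsubstituted phenyl in place of the chlorophenyl groups, would give a step beyond the scatter.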